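Pyridine in place of the sulfamoyl-thiadiazole on a shared core

A few compounds are considered here, and "the series" means these few. Any claim that something is new, unique, unknown or untested is made for them only; others in the source may bear on it.

Of the compounds shown here, three built on one shared core have been tested in a functional assay on MCF7 cells (Homo sapiens) for inhibition, read by MTT assay, with a stated time of 48 h; a lower number here means a stronger inhibitor, a higher number a weaker inhibitor. Compound 1, `CCOC(=O)C1=C(N/N=C(/Br)c2ccccc2)Nc2[nH]nc(C)c2C1c1ccc(N(C)C)cc1`, gives 78400 nM in this assay. Compound 2, `CCOC(=O)C1=C(N/C=N/c2nnc(S(N)(=O)=O)s2)Nc2[nH]nc(C)c2C1c1ccc(N(C)C)cc1`, gives 34500 nM in this assay. Compound 3, `CCOC(=O)C1=C(N/N=C(\c2ccc([N+](=O)[O-])cc2)N2CCN(c3ccc(F)cc3)CC2)Nc2[nH]nc(C)c2C1c1ccc(N(C)C)cc1`, reaches only the limit of this assay, > 100000 nM. Among the two numbers that are not limits, compound 2 stands lowest. Its nearest neighbour is compound 1. Going by the values given here, the gap between them is a 2.3-fold lower number from compound 1 to compound 2 (0.36 log units; beyond the scatter), and that is the only measured step in the set; it swaps one whole substituent for another on an amine nitrogen.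

Compound 4, `CCOC(=O)C1=C(N/C=N/c2ccccn2)Nc2[nH]nc(C)c2C1c1ccc(N(C)C)cc1`, differs from compound 2 in one place: pyridin-2-yl in place of 5-sulfamoyl-1,3,4-thiadiazol-2-yl on a double-bonded nitrogen. Among the compounds with values here, no measured step exchanges a group of this kind on a double-bonded nitrogen, so that single measured step, modest in size, is the only guide, and the one compound that reached the limit of this assay shows how weak this series is overall. The expectation is therefore a small move, upward if any, from the number of compound 2. For compound 4 the expected step is a 1.4-fold higher number from compound 2 to compound 4 (0.16 log units; within the scatter). Compound 4 is estimated at 50000 nM in this assay, with a range from 20000 nM to 100000 nM.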

Compound 4, half-maximal inhibitory concentration: 37300 nM
Beside the measured number, compound 4's estimate is 1.3-fold (0.13 log units) above it; the range from low to high includes it.
By their numbers in this assay, from the lowest: compounds 2 and 4 (each within the scatter of the next); then compound 1. At a limit, above all of these: compound 3.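

In this assay, the exchange on the double-bonded nitrogen cannot be read as a change at all: a 1.1-fold higher number from compound 2 to compound 4 (0.03 log units; within the scatter). Pyridin-2-yl thus takes the place of 5-sulfamoyl-1,3,4-thiadiazol-2-yl, and the sulfamoyl group and its hydrogen-bond donor go with it, without any difference beyond the scatter, so neither the sulfamoyl group nor the thiadiazole ring is needed at this position to hold the number where it stands. The earlier gap, a 2.3-fold lower number from compound 1 to compound 2 (0.36 log units; beyond the scatter), could have been credited to the sulfamoyl-thiadiazole, but the pyridine-bearing compound shows a gap of similar size, a 2.1-fold lower number from compound 1 to compound 4 (0.32 log units; beyond the scatter), which places the modest difference from compound 1 in something other than that particular ring; nothing in the data given accounts for the flat result itself.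

As far as these compounds go, whether any aromatic ring is needed on this nitrogen stays open, since a plain phenyl ring, a short alkyl chain or a primary amine in its place could give a different number. From the compounds shown here alone, it also stays open whether a carboxylic acid or another group here could move the number beyond the scatter at all.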